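Changing the group on the chain carbon of compound 2

A few compounds are considered here, and "the series" means these few. Any claim that something is new, unique, unknown or untested is made for them only; others in the source may bear on it.

In an ADME assay on microsomes from liver (Mus musculus) for metabolic stability, read by LC-MS, using NADPH, with stated times of 10 min and 30 min, tested at 1 uM (on this read-out higher numbers stand for fast clearance and lower numbers for slow clearance), compound 1 (`COC(=O)C1=C(CN2CCNCC2)NC(c2nccs2)=NC1(C)c1ccc(F)cc1`) gives 39 mL/min/kg and compound 2 (`COC(=O)C1=C(CN2CCCS2(=O)=O)NC(c2nccs2)=NC1(C)c1ccc(F)cc1`) gives 79 mL/min/kg as the higher of the two numbers. Compound 3 (`COC(=O)C1=C(CN(C)C2(C(=O)O)CC2)NC(c2nccs2)=NC1(C)c1ccc(F)cc1`) differs from compound 2 by one change, a group of 8 heavy atoms (5 carbon, 1 nitrogen, 2 oxygen; one three-membered non-aromatic ring of carbon only) in place of a group of 7 heavy atoms (3 carbon, 1 nitrogen, 2 oxygen, 1 sulfur; one five-membered non-aromatic ring with 2 hetero atoms), on a saturated chain carbon bound to a double-bonded ring carbon on a saturated chain carbon bound to a double-bonded ring carbon. Among the measured compounds shown here, the only measured step at that place is modest, a 2.0-fold higher number from compound 1 to compound 2 (0.31 log units; beyond the scatter) and it involves a different entering group, so it offers only a rough scale. A fall of similar size is expected, a 2.1-fold lower number from compound 2 to compound 3 (0.32 log units; beyond the scatter) as the estimate. For compound 3 the expected clearance is 38 mL/min/kg with 14 mL/min/kg to 75 mL/min/kg as the estimated range.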

Compound 3, clearance: 42 mL/min/kg
Compound 3: the middle estimate sits 1.1-fold (0.04 log units) below what was measured; the measured number falls inside the stated range.
By their numbers in this assay, from the lowest: compounds 1, 3 and 2 (each within the scatter of the next, the first and the last beyond it).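

At the saturated chain carbon bound to a double-bonded ring carbon, this assay now gives a 1.9-fold lower number from compound 2 to compound 3 (0.27 log units; within the scatter), so this change does not separate the two groups. It also gives a 1.1-fold higher number from compound 1 to compound 3 (0.03 log units; within the scatter), which shows that a group with a three-membered non-aromatic ring of carbon only and a group with a six-membered non-aromatic ring can stand at this place with no difference beyond the scatter. Nothing available explains these numbers. Still open, on these data alone, is how a simple amide, a primary amine or a longer chain at this place would read, and whether the carboxylic acid alone, without the three-membered ring, would read the same.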